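A few compounds are considered here, and "the series" means these few. Any claim that something is new, unique, unknown or untested is made for them only; others in the source may bear on it.

Three members of the series share one core and differ only in the group on a nitrogen on an aromatic ring. Compound 1 is `Cc1cc(NC(C)C)nc(SCc2nc3ccccc3[nH]2)n1`. In a functional assay on MCF7 cells (Homo sapiens) for cytotoxicity, read by MTT assay, with a stated time of 72 h (a higher number here means a weaker inhibitor, a lower number a stronger inhibitor), compound 1 returns only a limit, > 100000 nM. Compound 2 is `Cc1cc(NCCO)nc(SCc2nc3ccccc3[nH]2)n1`. In this assay compound 2 likewise returns a limit, > 100000 nM. Compound 3 is `COc1ccccc1Nc1cc(C)nc(SCc2nc3ccccc3[nH]2)n1`. In this assay compound 3 also returns a limit, > 100000 nM. Because all three sit at the limit of > 100000 nM in this assay, at which 3 of the 3 values shown sit, none of the steps between them can be read: a step that the two limits leave unreadable from compound 1 to compound 2, a step that the two limits leave unreadable from compound 1 to compound 3, a step that the two limits leave unreadable from compound 2 to compound 3. Compound 3 thus stands at the limit, with no number that would rank it against compound 1 or compound 2.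

Compound 4 is `Cc1ccc(Nc2cc(C)nc(SCc3nc4ccccc4[nH]3)n2)cc1`. It differs from compound 3 by 4-methylphenyl in place of 2-methoxyphenyl on a nitrogen on an aromatic ring. The measured steps that bear on this change are the two that exchange the group on that nitrogen into compound 3, a step that the two limits leave unreadable from compound 1 to compound 3 and a step that the two limits leave unreadable from compound 2 to compound 3, and both are unreadable, so they set no expected size or direction for the step in this assay. Going by the values given here, with every value so far at a limit, the expectation for compound 4 is that it most likely returns a limit as well. The step expected from compound 3 to compound 4 is a step that the limit leaves unreadable from compound 3 to compound 4. Compound 4 is estimated at 150000 nM, within a range from 40000 nM to 600000 nM.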

Compound 4, half-maximal inhibitory concentration: 56500 nM
Beside the measured number, compound 4's estimate is 2.7-fold (0.42 log units) above it; measured number inside the range.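

Going by these compounds alone, with 4-methylphenyl on the nitrogen, compound 4 gives 56500 nM in this assay, the only number among the four compounds rather than a limit. Set against the three limits, this yields floors only: an at least 1.7-fold lower number from compound 3 to compound 4 (0.24 log units; that floor lies within the scatter), an at least 1.7-fold lower number from compound 2 to compound 4 (0.24 log units; that floor lies within the scatter) and an at least 1.7-fold lower number from compound 1 to compound 4 (0.24 log units; that floor lies within the scatter), so the real size of each step remains unknown. An aromatic ring on that nitrogen does not by itself bring a readable number, as compound 3, with 2-methoxyphenyl, stays at the limit: the limit of > 100000 nM in this assay, at which 3 of the 4 values shown sit.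

The exchange from 2-methoxyphenyl to 4-methylphenyl alters both the substituent and its place on the ring, so the compounds shown cannot say which of the two matters in this assay. As far as these compounds go, how a plain phenyl, a 4-methoxyphenyl or a 2-methylphenyl on the same nitrogen would read remains open, and these would separate the two changes.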